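Replacing an Allyl Chain with a Chlorobenzyl Group

The source may report more compounds than this note shows. Statements on the series, on what has been measured and on what is new or still open speak of the compounds shown alone.

Three compounds share one core. In an ADME assay on MT4 cells (Homo sapiens) for cytotoxicity, read by MTT assay, with a stated time of 5 days (on this read-out higher numbers stand for lower toxicity in this test and lower numbers for higher toxicity in this test), compound 2 `CC(C)=CCN1C(=O)N(Cc2ccccc2)S(=O)(=O)n2cccc21` gives 226000 nM. Compound 1 `O=C1N(Cc2ccccc2)c2cccn2S(=O)(=O)N1Cc1cccc(F)c1` reaches only a limit of this assay at > 288000 nM. Compound 3 `C=CCN1C(=O)N(Cc2ccccc2)S(=O)(=O)n2cccc21` likewise stands at a limit of this assay, > 802000 nM, so no exact number is known for it. The measured step of an at least 3.5-fold higher number from compound 2 to compound 3 (0.55 log units; beyond the scatter) is the only one recorded, and it concerns a change within the chain rather than the entry of a ring. Compound 4 `O=C1N(Cc2ccccc2Cl)c2cccn2S(=O)(=O)N1Cc1ccccc1` differs from compound 3 by 2-chlorophenyl in place of vinyl on a saturated chain carbon bound to an amide-type nitrogen in a ring. With compound 1 also sitting at a limit, a small step of an at least 2.2-fold lower number from compound 3 to compound 4 (0.36 log units; beyond the scatter) is expected, likely again ending at a limit. Compound 4 is therefore estimated at 350000 nM, between 120000 nM and 900000 nM.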

Compound 4, half-maximal cytotoxic concentration: > 291000 nM
Compound 4: a limit, no number; the forecaster's own chance of this, stated with the estimate: 60%; the middle value lies beyond the limit too.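

With 2-chlorobenzyl in place of allyl, an aromatic ring now sits on this chain carbon, and in this assay compound 4 again gives a limit, not a number: the limit of > 291000 nM in this assay, at which 1 of the 4 values shown sits. Against the one exact value in the series, the result is an at least 1.2-fold higher number from compound 2 to compound 4 (0.10 log units; that floor lies within the scatter), so compound 4 cannot be told apart from compound 2. The step from compound 3 to compound 4 cannot be read, as both values are limits.

Exact values for compound 3 and compound 4 remain unknown. As far as these compounds go, it also remains open how this read-out would respond to a chain ending in an amine or a carboxylic acid at this place.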